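A few compounds are considered here, and "the series" means these few. Any claim that something is new, unique, unknown or untested is made for them only; others in the source may bear on it.

Measured so far in a functional assay on PC-3 cells (Homo sapiens) for inhibition, read by MTT assay, with a stated time of 48 h; on this read-out higher numbers stand for weaker inhibition and lower numbers for stronger inhibition:
- compound 1 `COc1ccc(-n2c(SCC(=O)c3ccc(OC)c(O)c3)nnc2-c2cc(OC)c(OC)c(OC)c2)cc1`: > 60000 nM (a limit)
- compound 2 `COc1cc(-c2nnc(S)n2-c2ccc(N(C)C)cc2)cc(OC)c1OC`: > 60000 nM (a limit)
- compound 3 `COc1cc(-c2nnc(SCc3ccc(F)cc3)n2-c2ccc(N(C)C)cc2)cc(OC)c1OC`: 46500 nM

Among the measured compounds shown here, compound 3 holds the only actual number, as the other two values are limits. The next compound is compound 4 `COc1ccc(C(=O)CSc2nnc(-c3cc(OC)c(OC)c(OC)c3)n2-c2ccc(N(C)C)cc2)cc1O`, and its difference from compound 3 is (3-hydroxy-4-methoxyphenyl)carbonyl in place of 4-fluorophenyl on a saturated chain carbon bound to a sulfur. In words, (3-hydroxy-4-methoxyphenyl)carbonyl stands in place of 4-fluorophenyl on a saturated chain carbon bound to a sulfur.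

For the measured compounds named here, one measured step bears on this change: an at least 1.2-fold lower number from compound 2 to compound 3 (0.11 log units; that floor lies within the scatter). It also concerns the group on sulfur, and its floor lies within the scatter, so it gives no firm size to carry over. The ((3-hydroxy-4-methoxyphenyl)carbonyl)methyl group of compound 4 also stands on the sulfur of compound 1, though the two differ elsewhere. Compound 1 gives only a limit, > 60000 nM. Going by the values given here, the series so far sits close to the limit of > 60000 nM in this assay, at which 2 of the 3 values shown sit, and a limit is a realistic outcome for the next compound too.

No step beyond the scatter is expected in this assay, and the expected step is a 1.2-fold lower number from compound 3 to compound 4 (0.07 log units; within the scatter). Compound 4 is estimated at 40000 nM, with an expected range of 8000 nM to 60000 nM.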

Compound 4, half-maximal inhibitory concentration: > 100000 nM
Compound 4: only a limit was reported; the forecaster's own chance of this, stated with the estimate: 45%; middle value at least 2.5-fold (0.39 log units) from the limit.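

In this assay, among the compounds shown here, (3-hydroxy-4-methoxyphenyl)carbonyl in place of 4-fluorophenyl on a saturated chain carbon bound to a sulfur gives an at least 2.1-fold higher number from compound 3 to compound 4 (0.33 log units; beyond the scatter), the first step beyond the scatter and the first sign that the group on sulfur can move this read-out. Because compound 4 gives only a limit, that step is a floor and its full size is not known: the limit of > 100000 nM in this assay, at which 1 of the 4 values shown sits. The ((3-hydroxy-4-methoxyphenyl)carbonyl)methyl group now gives no actual number with either methoxy (compound 1) or dimethylamino (compound 4) on the aromatic carbon, and the steps to compound 4 from compound 1 and from compound 2 cannot be read, since both ends are limits.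

The compounds shown do not separate the carbonyl from the hydroxy and methoxy groups within the entering group, and a 3-hydroxy-4-methoxybenzyl group on the sulfur would address that split. For the compounds shown here, with compound 3 the only compound holding an actual number, it also remains open whether any group on sulfur, such as a longer alkyl chain or an amine-bearing chain, would lower the number at all.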